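Trading the Ether Arm for a Plain Tert-Butyl Group

The source may report more compounds than this note shows. Statements on the series, on what has been measured and on what is new or still open speak of the compounds shown alone.

Measured so far:
compound 1, `O=C(NCc1cc(Cl)ccc1-n1cnnn1)[C@@H]1C[C@@H]2C[C@@H]2N1C(=O)[C@H](O)Cc1ccccn1`, 1000 nM
compound 2, `CC(C)(C)OC[C@@H](O)C(=O)N1[C@H](C(=O)NCc2cc(Cl)ccc2-n2cnnn2)C[C@@H]2C[C@@H]21`, 500 nM

In a functional assay on a cell-free system (plasma, Homo sapiens), with a stated time of 3 min (a higher number here means a weaker inhibitor, a lower number a stronger inhibitor), compound 2 holds the lowest of the two numbers recorded, and its nearest neighbour is compound 1, reached by a 2.0-fold lower number from compound 1 to compound 2 (0.30 log units; within the scatter), a step the scatter of the method can account for. Compound 3, `CC(C)(C)[C@@H](O)C(=O)N1[C@H](C(=O)NCc2cc(Cl)ccc2-n2cnnn2)C[C@@H]2C[C@@H]21`, is the next candidate; it differs from compound 2 by tert-butyl in place of (tert-butoxy)methyl on a saturated chain carbon bound to a carbonyl carbon and an oxygen on a saturated carbon. Within the data shown here, only one measured step exists to draw on, and it concerns a different substituent on the same chain; it was a 2.0-fold lower number from compound 1 to compound 2 (0.30 log units; within the scatter) and did not rise above the scatter. Among the measured compounds shown here, with no direct precedent for exchanging the (tert-butoxy)methyl group itself, compound 3 is expected to remain close to compound 2, with an estimated shift of no change at the digits printed from compound 2 to compound 3 (within the scatter). The estimate for compound 3 in this assay is therefore 500 nM, with a range from 200 nM to 1300 nM.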

Compound 3, half-maximal inhibitory concentration: 1500 nM
The estimate for compound 3 lay 3.0-fold (0.48 log units) below the measured number; measured number outside the range, above it.
By their numbers in this assay, from the lowest: compounds 2, 1 and 3 (each within the scatter of the next, the first and the last beyond it).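

In this assay, among these compounds, the saturated chain carbon bound to a carbonyl carbon and an oxygen on a saturated carbon now shows a change beyond the scatter: a 3.0-fold higher number from compound 2 to compound 3 (0.48 log units; beyond the scatter) is the only such step among the three compounds, and a modest one. Tert-butyl and (pyridin-2-yl)methyl are not separated at this position, since a 1.5-fold higher number from compound 1 to compound 3 (0.18 log units; within the scatter) stays within the scatter. No evidence is at hand that accounts for the step from (tert-butoxy)methyl to tert-butyl.

The change from compound 2 to compound 3 removes the ether oxygen and shortens the group in a single move, so the compounds shown cannot tell these two changes apart. As far as these compounds go, it also remains open how a methoxymethyl group, a primary amine or a carboxylic acid would fare on this carbon.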